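A few compounds are considered here, and "the series" means these few. Any claim that something is new, unique, unknown or untested is made for them only; others in the source may bear on it.

Compound 1 `CCCCCCOc1cccc(O)c1C(=O)/C=C/c1ccc(O)cc1` stands at the ceiling of a functional assay on NCI-H23 cells (Homo sapiens) for antiproliferative activity, read by sulforhodamine B assay; on this read-out lower numbers stand for stronger inhibition of growth and higher numbers for weaker inhibition of growth: it gives > 30000 nM, which is a limit of the assay and not a number. Compound 2 `O=C(/C=C/c1ccc(O)cc1)c1c(O)cccc1OCC1CCCCC1` likewise gives only a limit, > 30000 nM. Compound 3 `O=C(/C=C/c1ccc(O)cc1)c1c(O)cccc1OCCC1CCCC1` gives 3370 nM in this assay. Two steps are readable, an at least 8.9-fold lower number from compound 1 to compound 3 (0.94 log units; beyond the scatter) and an at least 8.9-fold lower number from compound 2 to compound 3 (0.94 log units; beyond the scatter); the third is a step that the two limits leave unreadable from compound 1 to compound 2. Compound 4 `CCC(CC)COc1cccc(O)c1C(=O)/C=C/c1ccc(O)cc1` differs from compound 1 by pentan-3-yl in place of pentyl on a saturated chain carbon bound to an oxygen on an aromatic ring. The branching thus sits on the saturated chain carbon bound to the oxygen on the aromatic ring, as in compound 2, which rests at the limit of > 30000 nM in this assay, at which 2 of the 3 values shown sit, whereas in compound 3 it sits two bonds along the chain. No step beyond the scatter is therefore expected; the estimated step is a step that the limit leaves unreadable from compound 1 to compound 4. Compound 4 is expected to give 40000 nM, between 8000 nM and 150000 nM.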

Compound 4, concentration for 50% growth inhibition: 3210 nM
Compound 4: middle estimate off by 12-fold (1.10 log units), on the high side, and the stated range ends above it.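

In this assay, branching on the saturated chain carbon bound to an oxygen on an aromatic ring does not by itself leave a compound at the ceiling, as the pentan-3-yl of compound 4 shows with an at least 9.3-fold lower number from compound 1 to compound 4 (0.97 log units; beyond the scatter) and an at least 9.3-fold lower number from compound 2 to compound 4 (0.97 log units; beyond the scatter); both steps start from limits of the assay, not from numbers. An open-chain branch also matches a ring-bearing chain here, with a 1.0-fold lower number from compound 3 to compound 4 (0.02 log units; within the scatter). The cyclohexyl of compound 2 thus stands apart from the pentan-3-yl, so the branch alone does not decide the outcome.

From the compounds shown here alone, how a shorter branched chain, or a branch ending in an amine or a carboxylic acid, would behave at this position remains open.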